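Swapping the sulfonyl aryl group in a squalene monooxygenase series

The source may report more compounds than this note shows. Statements on the series, on what has been measured and on what is new or still open speak of the compounds shown alone.

Of the compounds shown here, two have been measured in a functional assay on HepG2 cells for inhibition of squalene monooxygenase (Homo sapiens); a higher number here means a weaker inhibitor, a lower number a stronger inhibitor. Compound 2, `CCN(C/C=C/C#CC(C)(C)C)Cc1cccc(OCCN(C)S(=O)(=O)c2ccc(Br)cc2)c1`, gives 330 nM. Its nearest neighbour, compound 1, `CCN(C/C=C/C#CC(C)(C)C)Cc1cccc(OCCNS(=O)(=O)c2cccs2)c1`, gives 450 nM, and the gap between the two values lies within the usual scatter, so neither can be placed ahead of the other. Compound 3, `CCN(C/C=C/C#CC(C)(C)C)Cc1cccc(OCCN(C)S(=O)(=O)c2cc3ccccc3s2)c1`, has not yet been measured. It differs from compound 2 by 1-benzothiophen-2-yl in place of 4-bromophenyl on a sulfonyl sulfur. Among the measured compounds shown here, no step between measured compounds shows what such a change at the sulfonyl sulfur does; the two measured values only show that a thiophen-2-yl and a 4-bromophenyl at that position give much the same number. On that basis compound 3 is expected to stay close to compound 2, with a step of a 1.2-fold lower number from compound 2 to compound 3 (0.07 log units; within the scatter) that need not exceed the scatter. The estimate for compound 3 in this assay is 280 nM, within a range from 90 nM to 900 nM.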

Compound 3, half-maximal inhibitory concentration: 1800 nM
Compound 3: middle estimate off by 6.4-fold (0.81 log units), on the low side; the whole stated range lies below it.
By their numbers in this assay, from the lowest: compounds 2 and 1 (each within the scatter of the next); then compound 3.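

This step shows that the position on the sulfonyl sulfur is not indifferent to the aryl group it carries. In this assay, among the compounds shown here, 1-benzothiophen-2-yl in place of 4-bromophenyl gives a 5.5-fold higher number from compound 2 to compound 3 (0.74 log units; beyond the scatter), the only step here that isolates a change at this position, and it lies beyond the scatter towards a weaker inhibitor. No measured information is available to account for this step.

The compounds shown leave open whether the weaker inhibition follows from the second aromatic ring or from the ring sulfur of 1-benzothiophen-2-yl, a question that a naphthalen-2-yl group at the same place would help to separate. They also leave open how a smaller group such as phenyl or 4-chlorophenyl on the sulfonyl sulfur would compare with the 4-bromophenyl of compound 2.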